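This account rests on a few compounds, and the source may have more. Where it says the series, first, only, none or still open, it means among the compounds named here.

The measured compounds:
Compound 1, `CCn1c(C(=O)N(CCC#N)CCC#N)ccc1C(CC)(CC)c1ccc(OCCC(O)(CC)CC)c(C)c1`, gives in an assay on cells for agonist activity at vitamin D3 receptor (Homo sapiens), with a stated time of 96 h (on this read-out higher numbers stand for an effect only at larger amounts of compound and lower numbers for an effect already at smaller amounts), only a limit, > 10000 nM.
Compound 2, `CCOc1ccc(NC(=O)c2ccc(C(CC)(CC)c3ccc(OCCC(O)(CC)CC)c(C)c3)n2CC)cc1`, gives in this assay 1630 nM.

Among the numbers shown, compound 2 holds the only true number; the other entry is a limit (the limit of > 10000 nM in this assay, at which 1 of the 2 values shown sits). Among the compounds with values here, the single measured step, an at least 6.1-fold lower number from compound 1 to compound 2 (0.78 log units; beyond the scatter), went with a ring entering in place of a chain on the carbonyl carbon.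

Compound 3, `CCOC(=O)C(CC(=O)OC)NC(=O)c1ccc(C(CC)(CC)c2ccc(OCCC(O)(CC)CC)c(C)c2)n1CC`, differs from compound 2 by a group of 11 heavy atoms (7 carbon, 4 oxygen; no ring) in place of a group of 9 heavy atoms (8 carbon, 1 oxygen; one six-membered aromatic ring of carbon only), on an amide-type nitrogen. Within the data shown here, that change sits on the amide nitrogen, not on the carbonyl carbon, so no measured step matches it exactly; the nearest evidence is an at least 6.1-fold lower number from compound 1 to compound 2 (0.78 log units; beyond the scatter), where the ring came in and the number fell. Here the ring leaves again, so a step in the other direction, beyond the scatter, is expected as a 3.7-fold higher number from compound 2 to compound 3 (0.57 log units; beyond the scatter). Compound 3 is therefore estimated at 6000 nM, within 2000 nM to 20000 nM, with a real chance that only a limit is reported.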

Compound 3, half-maximal effective concentration: 21 nM
Compound 3: the middle estimate sits 290-fold (2.46 log units) above what was measured, and the stated range ends above it.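

Replacing the 4-ethoxyphenyl group on the amide-type nitrogen with an open chain carrying no ring gave, in this assay, a 78-fold lower number from compound 2 to compound 3 (1.89 log units; beyond the scatter), so a ring at this position is not needed for a low number, and compound 3 goes against the earlier pairing of a ring with a fall in the number. Compound 3 also stands well apart from the nitrile-bearing compound 1, with an at least 470-fold lower number from compound 1 to compound 3 (2.67 log units; beyond the scatter). Compound 1 gives only a limit, so that step has an open end: the limit of > 10000 nM in this assay, at which 1 of the 3 values shown sits.

The compounds shown do not tell which part of the entering chain goes with the step, the ethyl ester, the methyl ester or the chain itself. Nor do they tell how a carboxylic acid in place of either ester, or a plain alkyl chain on the same nitrogen, would read here.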